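Extending the acetamido chain of a macrolide by a hexyl group

The source may report more compounds than this note shows. Statements on the series, on what has been measured and on what is new or still open speak of the compounds shown alone.

Compound 1 `CC[C@H]1OC(=O)[C@H](C)[C@@H](O[C@H]2C[C@@](C)(OC)[C@@H](O)[C@H](C)O2)[C@H](C)[C@@H](O[C@@H]2O[C@H](C)C[C@H](N(C)CCCNC(C)=O)[C@H]2O)[C@](C)(OC)C[C@@H](C)C(=O)[C@H](C)[C@@H](O)[C@]1(C)O` is a macrolide carrying an acetamido group on a propyl arm of the sugar amine. In a physicochemical assay for lipophilicity, read by HPLC, measured as chromatographic lipophilicity, at pH 7.4 (a lower number here means a more polar compound, a higher number a more lipophilic compound), compound 1 gives 3.08. Two related compounds are known in the same measurement. Compound 3 `CC[C@H]1OC(=O)[C@H](C)[C@@H](O[C@H]2C[C@@](C)(OC)[C@@H](OCCCNC(C)=O)[C@H](C)O2)[C@H](C)[C@@H](O[C@@H]2O[C@H](C)C[C@H](N(C)C)[C@H]2O)[C@](C)(OC)C[C@@H](C)C(=O)[C@H](C)[C@@H](O)[C@]1(C)O` gives 3.08, and compound 1 stands level with compound 3 at the digits recorded, the two together being the highest of the three numbers, within the scatter of each other. Going by the values given here, compound 2 `CCC(=O)NCCCO[C@@H]1[C@@H](C)N(C)C[C@H](C)C[C@@](C)(O)[C@H](O[C@@H]2O[C@H](C)C[C@H](N(C)C)[C@H]2O)[C@@H](C)[C@H](O[C@H]2C[C@@](C)(OC)[C@@H](O)[C@H](C)O2)[C@@H](C)C(=O)O[C@H](CC)[C@@]1(C)O` gives 2.74, a number lower than that of compound 1 beyond the scatter, and compound 2 is the one furthest from compound 1.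

Compound 4 `CCCCCCCC(=O)NCCCN(C)[C@H]1C[C@@H](C)O[C@@H](O[C@@H]2[C@@H](C)[C@H](O[C@H]3C[C@@](C)(OC)[C@@H](O)[C@H](C)O3)[C@@H](C)C(=O)O[C@H](CC)[C@@](C)(O)[C@H](O)[C@@H](C)C(=O)[C@H](C)C[C@@]2(C)OC)[C@@H]1O` has not yet been measured. It differs from compound 1 in one place: hexyl in place of hydrogen on a saturated chain carbon bound to a carbonyl carbon. Among the compounds with values here, no comparable step between measured compounds exists here, so the size of this change cannot be read from the three values above. Compound 4 is nevertheless expected to move upward in this assay by a clearly visible margin, the step of a number 1.92 log units higher from compound 1 to compound 4 (beyond the scatter) being estimated to lie well beyond the scatter. For compound 4 the estimate is 5, with a plausible range from 4.3 to 5.7.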

Compound 4, distribution coefficient: 6.44
The estimate for compound 4 lay 1.44 log units below the measured number; the whole stated range lies below it.
By their numbers in this assay, from the lowest: compound 2; then compounds 1 and 3 (each within the scatter of the next); then compound 4.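

Going by these compounds alone, this is the first step in the set that changes the chain end of the acetamido group alone. The earlier compounds shown here differ from one another in more than one place. In this assay, hexyl in place of hydrogen on a saturated chain carbon bound to a carbonyl carbon gives a number 3.36 log units higher from compound 1 to compound 4 (beyond the scatter), a large step. The position is therefore not silent in this measurement: a single change there, turning acetamido into (heptylcarbonyl)amino, moves the number far beyond the scatter. Nothing shown explains the size of this step.

With only one chain length in hand, the compounds shown leave open how the number builds up along the way, as an ethyl or butyl group or a longer chain might reveal. They also leave open what an amine or a carboxylic acid at the end of the same chain would do.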